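This account rests on a few compounds, and the source may have more. Where it says the series, first, only, none or still open, it means among the compounds named here.

Measured in a functional assay on the whole organism (strain Icem-CET (SPF Caw)) for inhibition, with Mus musculus as the target, with a stated time of 30 min; a lower number here means that less compound is needed, a higher number that more compound is needed for the effect:
Compound 1, `C#CCNC(=O)/C(C)=C(\C)c1ccc(Br)cc1`, gives 18.4 mg/kg.
Compound 2, `C/C(C(=O)NC1CC1)=C(/C)c1ccc(F)cc1`, gives 25 mg/kg.
Compound 3, `C#CCNC(=O)/C(C)=C(\C)c1ccc(Cl)cc1`, gives 10.6 mg/kg.

Compound 3 has the lowest number of the three. Its nearest neighbour is compound 1, and the step of a 1.7-fold lower number from compound 1 to compound 3 (0.24 log units; within the scatter) is within the scatter, so the two cannot be told apart. Compound 2, which carries a different amide and a fluoro group, sits furthest off with a higher number.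

Compound 4, `C#CCNC(=O)/C(C)=C(\C)c1ccc(C)cc1`, differs from compound 3 in one place: methyl in place of chloro on an aromatic carbon. For the measured compounds named here, the only measured step at this position, a 1.7-fold lower number from compound 1 to compound 3 (0.24 log units; within the scatter), swapped one halogen for another and stayed within the scatter. Going by the values given here, no measured step swaps a halogen for a methyl group, so the change to compound 4 has no direct precedent here. Given that the one change at this position in compound 1 and compound 3 moved little, a modest step is expected, and compound 4 is estimated at 15 mg/kg (range 7 mg/kg to 35 mg/kg), which means an expected step of a 1.4-fold higher number from compound 3 to compound 4 (0.15 log units; within the scatter).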

Compound 4, dose for half-maximal effect: 86.4 mg/kg
Beside the measured number, compound 4's estimate is 5.8-fold (0.76 log units) below it; measured number outside the range, above it.
By their numbers in this assay, from the lowest: compounds 3, 1 and 2 (each within the scatter of the next, the first and the last beyond it); then compound 4.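

In this assay, this aromatic carbon turns out to be sensitive to the group it carries: the step of an 8.2-fold higher number from compound 3 to compound 4 (0.91 log units; beyond the scatter) and the step of a 4.7-fold higher number from compound 1 to compound 4 (0.67 log units; beyond the scatter) both lie beyond the scatter, whereas the halogen swap, a 1.7-fold lower number from compound 1 to compound 3 (0.24 log units; within the scatter), stayed within it. Among these three compounds with the same amide, the two with a halogen at this position need less compound for the effect than the one with methyl. Nothing available here accounts for this gap.

Going by these compounds, with only chloro, bromo and methyl compared on this amide, it remains open whether other halogens behave alike, since compound 2 differs from these compounds in its amide as well as its fluoro group. On these data alone, it is also open where a methoxy group, an amine or a longer chain such as ethyl would fall at this position.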